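From trimethoxyphenyl to furan-2-yl on a carbonyl carbon

The compounds below may be only part of what the source reports. "The series", "measured", "known", "first", "only" and "open" are said of these compounds alone.

Of the compounds shown here, three sharing one core have been tested in a functional assay on SW48 cells (Homo sapiens) for antiproliferative activity, read by MTT assay, with a stated time of 72 h (a lower number here means a stronger inhibitor, a higher number a weaker inhibitor), and they differ only in the group on a carbonyl carbon. Compound 1 `COc1ccc([C@H]2[C@H](NC(=O)c3ccc(F)cc3)C(=O)N2c2cc(OC)c(OC)c(OC)c2)cc1O` gives 384 nM, compound 2 `COc1ccc(C(=O)N[C@@H]2C(=O)N(c3cc(OC)c(OC)c(OC)c3)[C@H]2c2ccc(OC)c(O)c2)cc1` gives 108 nM, and compound 3 `COc1ccc([C@H]2[C@H](NC(=O)c3cc(OC)c(OC)c(OC)c3)C(=O)N2c2cc(OC)c(OC)c(OC)c2)cc1O` gives 564 nM. Changing that group to 3,4,5-trimethoxyphenyl gives a 1.5-fold higher number from compound 1 to compound 3 (0.17 log units; within the scatter) and a 5.2-fold higher number from compound 2 to compound 3 (0.72 log units; beyond the scatter). Compound 3 therefore cannot be told apart from compound 1, and stands clearly apart only from compound 2.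

Compound 4 `COc1ccc([C@H]2[C@H](NC(=O)c3ccco3)C(=O)N2c2cc(OC)c(OC)c(OC)c2)cc1O` changes the same place: furan-2-yl in place of 3,4,5-trimethoxyphenyl on a carbonyl carbon. In words, furan-2-yl replaces 3,4,5-trimethoxyphenyl on a carbonyl carbon. The two steps show that this place can matter, as with compound 2 at 108 nM, or barely matter, as with compound 1 at 384 nM. Among the measured compounds shown here, no furan-2-yl compound has been measured to settle the direction. The estimated change in this assay is a 1.9-fold lower number from compound 3 to compound 4 (0.27 log units; within the scatter), so no step beyond the scatter is expected. Compound 4 is estimated at 300 nM, with an expected range of 90 nM to 1000 nM.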

Compound 4, half-maximal inhibitory concentration: 18.6 nM
The estimate for compound 4 lay 16-fold (1.21 log units) above the measured number; measured number outside the range, below it.
By their numbers in this assay, from the lowest: compound 4; then compound 2; then compounds 1 and 3 (each within the scatter of the next).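

Furan-2-yl on this carbonyl carbon gives a 30-fold lower number from compound 3 to compound 4 (1.48 log units; beyond the scatter) in this assay and also a 21-fold lower number from compound 1 to compound 4 (1.31 log units; beyond the scatter) and a 5.8-fold lower number from compound 2 to compound 4 (0.76 log units; beyond the scatter) so the position can move the number much further than the earlier compounds showed. All three steps lie beyond the scatter, which makes compound 4 the strongest of the four and shows that a five-membered aromatic ring with 1 hetero atom can outdo all three six-membered aromatic rings tested here. Nothing measured here explains why this change has so large an effect.

From the compounds shown here alone, it remains open whether the gain depends on the ring oxygen or on the smaller group as a whole: a thiophen-2-yl group, with sulfur in place of that oxygen, or an unsubstituted phenyl group would help separate the two. These compounds also leave open whether the same order holds in other cell lines.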